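Trifluoromethyl for Fluoro on a Shared Core

This account rests on a few compounds, and the source may have more. Where it says the series, first, only, none or still open, it means among the compounds named here.

Compound 1 `CC(=O)Nc1ccc2oc(-c3cccc(F)c3)cc(=O)c2c1` and compound 2 `CC(=O)Nc1ccc2oc(-c3cccc(C(F)(F)F)c3)cc(=O)c2c1` share one core and differ by trifluoromethyl in place of fluoro on an aromatic carbon. In an ADME assay on MT4 cells (Homo sapiens) for cytotoxicity, read by MTT assay, with a stated time of 4 days (on this read-out higher numbers stand for lower toxicity in this test and lower numbers for higher toxicity in this test), compound 1 gives 240000 nM, and compound 2 gives 10000 nM; the step of a 24-fold lower number from compound 1 to compound 2 (1.38 log units; beyond the scatter) is a large one. Compound 3 `Nc1ccc2oc(-c3cccc(F)c3)cc(=O)c2c1` differs from compound 1 by hydrogen in place of acetyl on a nitrogen on an aromatic ring; in this assay compound 3 gives 269000 nM, and the step of a 1.1-fold higher number from compound 1 to compound 3 (0.05 log units; within the scatter) stays within the scatter. Compound 4 `Nc1ccc2oc(-c3cccc(C(F)(F)F)c3)cc(=O)c2c1` has not been measured and differs from compound 3 by trifluoromethyl in place of fluoro on an aromatic carbon, the same change that carried compound 1 to compound 2. Because a 24-fold lower number from compound 1 to compound 2 (1.38 log units; beyond the scatter) was large, a step of similar size is expected from compound 3 to compound 4, namely a 24-fold lower number from compound 3 to compound 4 (1.39 log units; beyond the scatter). The estimate for compound 4 in this assay is 11000 nM, expected to fall between 4000 nM and 40000 nM.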

Compound 4, half-maximal cytotoxic concentration: 138000 nM
Compound 4: the middle estimate sits 13-fold (1.10 log units) below what was measured; measured number above the stated range.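

On the core of compound 3, trifluoromethyl in place of fluoro gives a 1.9-fold lower number from compound 3 to compound 4 (0.29 log units; within the scatter) in this assay, so the large step seen on the core of compound 1 does not carry over at the same size: the same change on two cores in this assay, a 24-fold lower number (1.38 log units; beyond the scatter) from compound 1 to compound 2 and a 1.9-fold lower number (0.29 log units; within the scatter) from compound 3 to compound 4, 12-fold (1.09 log units) apart, beyond the scatter of two such steps. Read the other way, hydrogen in place of acetyl now gives a 14-fold higher number from compound 2 to compound 4 (1.14 log units; beyond the scatter) instead of a step within the scatter: the same change on two cores in this assay, a 1.1-fold higher number (0.05 log units; within the scatter) from compound 1 to compound 3 and a 14-fold higher number (1.14 log units; beyond the scatter) from compound 2 to compound 4, 12-fold (1.09 log units) apart, beyond the scatter of two such steps. The two changes therefore do not add independently across these four compounds, but a single set of four does not show why, or how the change would behave on any other core.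

Going by these compounds, it remains open whether a chloro or methoxy group in place of fluoro would show the same dependence on the group on the nitrogen. The same question stands for a longer acyl chain or a sulfonamide in place of acetyl.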